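The source may report more compounds than this note shows. Statements on the series, on what has been measured and on what is new or still open speak of the compounds shown alone.

For the measured compounds named here, compound 2, with the structure `O=C(Nc1ccc(Cl)cc1)c1ccc(/N=N\c2c[nH]c3ccccc23)cc1`, stands at the higher end of the two numbers so far: in a functional assay on HCT-116 cells (Homo sapiens) for inhibition, read by MTT assay, with a stated time of 72 h (on this read-out higher numbers stand for weaker inhibition and lower numbers for stronger inhibition), compound 2 gives 187000 nM. Its nearest neighbour is compound 1, with the structure `Cc1ccc(NC(=O)c2ccc(/N=N\c3c[nH]c4ccccc34)cc2)c(C)c1`, which in this assay gives 76100 nM. Going by the values given here, the one step measured between them, a 2.5-fold higher number from compound 1 to compound 2 (0.39 log units; beyond the scatter), changes the group on the amide-type nitrogen and moves the number modestly.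

Compound 3, with the structure `O=C(Nc1cccc([N+](=O)[O-])c1)c1ccc(/N=N\c2c[nH]c3ccccc23)cc1`, has not yet been measured. It differs from compound 2 by 3-nitrophenyl in place of 4-chlorophenyl on an amide-type nitrogen. Among the compounds with values here, the only measured step that bears on this change is the one from compound 1 to compound 2, since it alters the same group on the same nitrogen, but it involves a different pair of groups, so it tells only that the numbers in this assay shift modestly when that group is exchanged. On that basis no step beyond the scatter is expected from compound 2 to compound 3, and the expected step is a 1.2-fold lower number from compound 2 to compound 3 (0.10 log units; within the scatter). For compound 3 the estimated value in this assay is 150000 nM, with a range from 50000 nM to 450000 nM.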

Compound 3, half-maximal inhibitory concentration: 70100 nM
Compound 3: middle estimate off by 2.1-fold (0.33 log units), on the high side; the range from low to high includes it.
By their numbers in this assay, from the lowest: compounds 3 and 1 (each within the scatter of the next); then compound 2.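

In this assay, 3-nitrophenyl in place of 4-chlorophenyl on the amide-type nitrogen gives a 2.7-fold lower number from compound 2 to compound 3 (0.43 log units; beyond the scatter), so this position, which had so far shown only a rise in the number, can also lower it, and compound 2 now stands as the weakest of the three. The change from the 2,4-dimethylphenyl group gives a 1.1-fold lower number from compound 1 to compound 3 (0.04 log units; within the scatter), so two groups with different names and different atoms leave the number in the same place, and the 4-chlorophenyl group alone sets itself apart. Nothing available explains why the 4-chlorophenyl group differs from the other two.

The compounds shown leave open whether the difference follows the kind of group or where it sits on the phenyl ring, a question that a 4-nitrophenyl or a 3-chlorophenyl group on the same nitrogen would address. They also leave open whether an amine, as in a 3-aminophenyl group, or a carboxylic acid on that ring, or a plain phenyl with no added group, would move the number beyond the narrow band these three occupy.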